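The source may report more compounds than this note shows. Statements on the series, on what has been measured and on what is new or still open speak of the compounds shown alone.

Compound 2 `O=C(O)CSc1ccn([C@@H]2O[C@H](COP(=O)(O)OP(=O)(O)O)[C@@H](O)[C@H]2O)c(=O)n1` gives 1700 nM in an in vitro functional assay on 1321-N1 cells for agonist activity at P2Y purinoceptor 6 (Homo sapiens); on this read-out higher numbers stand for an effect only at larger amounts of compound and lower numbers for an effect already at smaller amounts. That is the lower of the two numbers measured, but compound 1 `Cn1c(=O)ccn([C@@H]2O[C@H](COP(=O)(O)OP(=O)(O)O)[C@@H](O)[C@H]2O)c1=O`, which gives 3300 nM in this assay, sits within the scatter of it, so no order between the two can be read. Compound 3 `CCSc1ccn([C@@H]2O[C@H](COP(=O)(O)OP(=O)(O)O)[C@@H](O)[C@H]2O)c(=O)n1` differs from compound 2 by methyl in place of carboxy on a saturated chain carbon bound to a sulfur. For the measured compounds named here, no measured pair shows this change, so the size of the step from compound 2 to compound 3 is uncertain; a small move toward a higher number, not clearly beyond the scatter, is expected, as a 1.8-fold higher number from compound 2 to compound 3 (0.25 log units; within the scatter). Compound 3 is therefore estimated at 3000 nM, with a range from 800 nM to 12000 nM.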

Compound 3, half-maximal effective concentration: 280 nM
Compound 3: the middle estimate sits 11-fold (1.03 log units) above what was measured, outside the stated range (below it).
By their numbers in this assay, from the lowest: compound 3; then compounds 2 and 1 (each within the scatter of the next).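

With methyl in place of carboxy on a saturated chain carbon bound to a sulfur, this assay shows a 6.1-fold lower number from compound 2 to compound 3 (0.78 log units; beyond the scatter) as a step beyond the scatter. For the compounds shown here, this is the first sign that the number responds to what this chain carries, and ethylsulfanyl now gives the lowest number of the three compounds. Nothing measured here explains the step. From the compounds shown here alone, whether a longer chain or an amine on this carbon would lower the number further remains open. So does whether a carboxylic acid further along a longer chain would raise it.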